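Sulfonamide-linked bipiperidine series: cytotoxicity working notes

A few compounds are considered here, and "the series" means these few. Any claim that something is new, unique, unknown or untested is made for them only; others in the source may bear on it.

Measured so far:
compound 1 `Cc1cc(C)c(S(=O)(=O)N2CCC(N3CCC(O)CC3)CC2)c(C)c1` — > 5000 nM
compound 2 `Cc1cc(C)cc(-c2cccc(S(=O)(=O)N3CCC(N4CCC(C)CC4)CC3)c2)c1` — > 5000 nM

In an ADME assay on HCT-116 cells (Homo sapiens) for cytotoxicity, read by CellTiter-Glo, with a stated time of 72 h (a higher number here means a weaker inhibitor, a lower number a stronger inhibitor), compound 1 reaches only the limit of the assay, > 5000 nM. In the same assay compound 2 likewise returns only a limit, > 5000 nM. Compound 2 therefore stands at the limit of > 5000 nM in this assay, at which 2 of the 2 values shown sit, and no ordering between compound 1 and compound 2 can be drawn from these two readings; neither is known to be the weaker or the stronger.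

The next compound in the set is compound 3 `COc1cccc(S(=O)(=O)N2CCC(N3CCC(C)CC3)CC2)c1`. It differs from compound 2 at one place: methoxy in place of 3,5-dimethylphenyl on an aromatic carbon. Within the data shown here, no step between two measured compounds is available in this assay, so the size of the change cannot be anchored to a measured pair. Given that compound 2 sits at the limit > 5000 nM, the expectation for compound 3 in this assay is a step of no clear direction and not beyond the scatter, a step that the limit leaves unreadable from compound 2 to compound 3. Compound 3 is expected to give about 8000 nM, within a range of 3000 nM to 30000 nM, most likely reported again as a limit.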

Compound 3, half-maximal inhibitory concentration: > 5000 nM
Compound 3 was reported as a limit (the forecaster's own chance of this, stated with the estimate: 80%); the middle value does not contradict the limit.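

In this assay compound 3 gives > 5000 nM as a limit of the assay. Compound 2 also gave only a limit, so no step from compound 2 to compound 3 can be read, and the position of the series remains: the limit of > 5000 nM in this assay, at which 3 of the 3 values shown sit.

The compounds shown leave open whether any of them has a measurable value in this assay and how methoxy compares with 3,5-dimethylphenyl there.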